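Naphthalenyl in place of tolyl on the pyran core

The source may hold more compounds than are shown below. What is called first, only, known or untested is meant among the compounds shown, and "the series" means these compounds.

Compound 3 `Cc1ccc(C2C(C#N)=C(N)OC(c3c[nH]c4ccccc34)=C2C#N)cc1` gives 6.2% in a functional assay, tested at 200 ug/mL (a lower number here means a weaker effect, a higher number a stronger effect of the compound at the concentration tested), the lower of the two numbers reported; compound 2 `CN(C)c1ccc(C2C(C#N)=C(N)OC(c3c[nH]c4ccccc34)=C2C#N)cc1` gives 20.5%, and compound 1 `N#CC1=C(N)OC(c2c[nH]c3ccccc23)=C(C#N)C1c1ccc2ccccc2c1` is reported as "not active" (no number reported). Within the data shown here, the only measured step, a number 14.3 percentage points lower from compound 2 to compound 3 (beyond the scatter), concerns a change on the aromatic carbon and does not cover the change to compound 4 `N#CC1=C(N)OC(c2c[nH]c3ccccc23)=C(C#N)C1c1cccc2ccccc12`, which is naphthalen-1-yl in place of 4-methylphenyl on a saturated ring carbon. Among the measured compounds shown here, no measured step therefore bears directly on it, and the two values of compound 1 and compound 3 give no single number to compare. The account expects no step beyond the scatter, a number 0.2 percentage points lower from compound 3 to compound 4 (within the scatter), and estimates for compound 4 a value of 6%, between 0% and 18%.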

Compound 4, a percentage reported as activity, at one concentration (the size of the read-out at that concentration, not a potency): 7.7%
For compound 4 the middle estimate is 1.7 percentage points below the measured one; low and high end bracket the measured number.
By their numbers in this assay, from the lowest: compounds 3 and 4 (each within the scatter of the next); then compound 2.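

On the saturated ring carbon of the shared core, the larger all-carbon naphthalen-1-yl group and 4-methylphenyl cannot be told apart in this assay, with a number 1.5 percentage points higher from compound 3 to compound 4 (within the scatter). The same position gives a number 12.8 percentage points lower from compound 2 to compound 4 (beyond the scatter), so among the compounds with numbers, only the 4-(dimethylamino)phenyl group of compound 2 stands apart. Nothing available explains this difference. Still open, going by these compounds, is whether a phenyl ring bearing a free amino group, a hydroxyl or a carboxylic acid would match or exceed compound 2 in this assay.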